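Side-chain variation on the saturated chain carbon

The source may report more compounds than this note shows. Statements on the series, on what has been measured and on what is new or still open speak of the compounds shown alone.

Measured compounds:
Compound 1 `CNC(=O)C[C@@H]1C[C@@H](c2ccc(Cl)c(Cl)c2)[C@H](NC(=O)c2cc(-c3c(Cl)cnn3C)c(Cl)o2)CN1` — 2.64 nM
Compound 2 `Cn1ncc(Cl)c1-c1cc(C(=O)N[C@@H]2CN[C@H](CC(O)CO)C[C@H]2c2ccc(Cl)c(Cl)c2)oc1Cl` — 3.79 nM
Compound 3 `C=CC[C@@H]1C[C@@H](c2ccc(Cl)c(Cl)c2)[C@H](NC(=O)c2cc(-c3c(Cl)cnn3C)c(Cl)o2)CN1` — 12.4 nM

Compound 3 stands highest of the three in an assay for inhibition of RAC-alpha serine/threonine-protein kinase (Homo sapiens), read by HTRF, with a stated time of 1 h; on this read-out higher numbers stand for weaker inhibition and lower numbers for stronger inhibition; compound 2 lies a step below it and compound 1 furthest below, both gaps beyond the scatter. The new compound 4 `Cn1ncc(Cl)c1-c1cc(C(=O)N[C@@H]2CN[C@H](CC(=O)NC3CC3)C[C@H]2c2ccc(Cl)c(Cl)c2)oc1Cl` differs from compound 3 in one place: cyclopropylcarbamoyl in place of vinyl on a saturated chain carbon bound to a saturated ring carbon. Among the compounds with values here, two measured steps bear on this. Going from an amide side chain to vinyl cost potency: a 4.7-fold higher number from compound 1 to compound 3 (0.67 log units; beyond the scatter) and a 3.3-fold higher number from compound 2 to compound 3 (0.51 log units; beyond the scatter). Compound 4 reverses that direction, bringing back an amide with a cyclopropyl in place of methyl, so a modest drop in the number toward compound 1 is anticipated. The expected step is a 3.9-fold lower number from compound 3 to compound 4 (0.59 log units; beyond the scatter). Compound 4 is therefore expected near 3.2 nM, within 1.4 nM to 8 nM, because a 4.7-fold higher number from compound 1 to compound 3 (0.67 log units; beyond the scatter) shows the amide-to-vinyl change running the other way.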

Compound 4, half-maximal inhibitory concentration: 3.95 nM
Beside the measured number, compound 4's estimate is 1.2-fold (0.09 log units) below it, within the range that was stated.
By their numbers in this assay, from the lowest: compounds 1, 2 and 4 (each within the scatter of the next); then compound 3.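

In this assay, cyclopropylcarbamoyl on this saturated chain carbon restores the number lost with vinyl (a 3.1-fold lower number from compound 3 to compound 4 (0.50 log units; beyond the scatter)). Cyclopropyl in place of methyl on the amide-type nitrogen (a 1.5-fold higher number from compound 1 to compound 4 (0.17 log units; within the scatter)) and cyclopropylcarbamoyl in place of 1,2-dihydroxyethyl (a 1.0-fold higher number from compound 2 to compound 4 (0.02 log units; within the scatter)) both stay within the scatter, so neither change separates these side chains on this read-out. No measured evidence explains these steps.

Still open, as far as these compounds go, is how a carboxylic acid, a primary amine or a longer chain on this carbon would read. Also open, from the compounds shown here alone, is whether the amide hydrogen matters, a question that dimethylcarbamoyl could address.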